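A few compounds are considered here, and "the series" means these few. Any claim that something is new, unique, unknown or untested is made for them only; others in the source may bear on it.

Working notes on the series. Compound 1 `CC(=O)c1cccc(-c2ccc(C(=O)N(Cc3cccc(OCCCCCC(=O)O)c3)C(C)C)cc2)c1` is the reference point of the set. In an ADME assay on BJ cells (Homo sapiens) for cytotoxicity, read by CellTiter-Glo and resazurin assay, with a stated time of 72 h (on this read-out higher numbers stand for an effect only at larger amounts of compound and lower numbers for an effect already at smaller amounts), compound 1 gives > 26000 nM, which is a limit of the assay and not a number. Compound 2 `COc1cccc(-c2ccc(C(=O)N(Cc3cccc(OCCCCCC(=O)O)c3)C(C)C)cc2)c1` carries methoxy in place of acetyl on an aromatic carbon. In this assay compound 2 gives > 20900 nM, again a limit. Compound 3 `CCOC(=O)CCCCCOc1cccc(CN(C(=O)c2ccc(-c3cccc(C(C)=O)c3)cc2)C(C)C)c1` carries ethyl in place of hydrogen on an oxygen next to a carbonyl group. In this assay compound 3 gives > 26000 nM, likewise a limit.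

Compound 3 therefore stands where every other value of the set stands, at a limit, and neither a step that the two limits leave unreadable from compound 1 to compound 3 nor a step that the two limits leave unreadable from compound 1 to compound 2 can be sized. All that the measured steps show is the limit of > 20900 nM in this assay, at which 1 of the 3 values shown sits, and (the limit of > 26000 nM in this assay, at which 2 of the 3 values shown sit).

Compound 4 `CCOC(=O)CCCCCOc1cccc(CN(C(=O)c2ccc(-c3cccc(OC)c3)cc2)C(C)C)c1` differs from compound 3 by methoxy in place of acetyl on an aromatic carbon. The same change was made once before, a step that the two limits leave unreadable from compound 1 to compound 2, with both ends at a limit, so no direction or size is readable from it. For compound 4 no shift beyond the scatter in this assay is expected, and a step that the limit leaves unreadable from compound 3 to compound 4 is the estimated step. Compound 4 is expected to give about 40000 nM in this assay, within 15000 nM to 120000 nM, and most probably to be reported only as a limit once more.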

Compound 4, half-maximal effective concentration: > 21000 nM
Compound 4: no number, only a limit; the forecaster's own chance of this, stated with the estimate: 85%; the middle value is on the limit's open side.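

In this assay compound 4 gives > 21000 nM, which is a limit and not a number. Its steps from compound 3 and from compound 2 cannot be read, with both ends of each at a limit. The compounds shown leave open where the half-maximal effective concentration of any of the four lies, and whether either change shifts it.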